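The compounds below may be only part of what the source reports. "The series", "measured", "known", "first", "only" and "open" are said of these compounds alone.

Measured in a functional assay (aorta) with Oryctolagus cuniculus as the target; on this read-out lower numbers stand for tighter binding and higher numbers for weaker binding:
- compound 1 `COc1cc(C(C)=O)ccc1OCCCN1CCC(C(c2ccc(C)cc2)c2ccc(C)cc2)CC1`: 15.9 nM
- compound 2 `COc1cc(C(C)O)ccc1OCCCN1CCC(C(c2ccc(F)cc2)c2ccc(F)cc2)CC1`: 10 nM

Compound 2, at 10 nM, lies within the scatter of compound 1, at 15.9 nM, so these two numbers do not separate the compounds.

Compound 3 `CC(=O)c1ccc(OCCCN2CCC(C(c3ccc(F)cc3)c3ccc(F)cc3)CC2)cc1` has not yet been measured. It carries 4-acetylphenyl in place of 4-(1-hydroxyethyl)-2-methoxyphenyl on an oxygen on a saturated carbon. Among the compounds with values here, no measured pair shows this change on its own, so only a modest expectation is possible. The expected result is a small move toward a higher number, not beyond the scatter, a 1.5-fold higher number from compound 2 to compound 3 (0.18 log units; within the scatter). Compound 3 is estimated at 15 nM, with an expected range of 5 nM to 45 nM.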

Compound 3, dissociation constant: 2.51 nM
For compound 3 the middle estimate is 6.0-fold (0.78 log units) above the measured one; measured number outside the range, below it.
By their numbers in this assay, from the lowest: compound 3; then compounds 2 and 1 (each within the scatter of the next).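

In this assay, within the data shown here, the change on the oxygen gives a 4.0-fold lower number from compound 2 to compound 3 (0.60 log units; beyond the scatter) and is the first difference in this set that lies beyond the scatter, so this position responds to what it carries. Because the step removes the methoxy and swaps 1-hydroxyethyl for acetyl together, it cannot be assigned to either part. Nothing available accounts for the step.

The compounds shown leave open how 4-acetyl-2-methoxyphenyl or 4-(1-hydroxyethyl)phenyl would read on this core. They also leave open whether an amide or a carboxylic acid could stand in place of the acetyl.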